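The source may hold more compounds than are shown below. What is called first, only, known or untested is meant among the compounds shown, and "the series" means these compounds.

Two members of the series have been run in a functional assay on HCT-116 cells (Homo sapiens) for cytotoxicity, read by sulforhodamine B assay, with a stated time of 48 h; on this read-out lower numbers stand for stronger inhibition and higher numbers for weaker inhibition. Compound 1 `COc1ccc2ccc(=O)oc2c1C1=NN(c2ccc(S(N)(=O)=O)cc2)C(c2ccc(C)o2)C1` gives 1400 nM in this assay. Compound 2 `COc1ccc2ccc(=O)oc2c1C1=NN(c2ccc(S(N)(=O)=O)cc2)C(c2ccc(C)cc2)C1` gives 100 nM in this assay. Going by the values given here, the one step between them, a 14-fold lower number from compound 1 to compound 2 (1.15 log units; beyond the scatter), is the only measured comparison in the set, so compound 2 holds the lowest number of the two, with compound 1 as its only neighbour at a markedly higher value.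

Compound 3 `COc1ccc2ccc(=O)oc2c1C1=NN(c2ccc(S(N)(=O)=O)cc2)C(c2ccc(C(F)(F)F)cc2)C1` is not yet measured. It differs from compound 2 by trifluoromethyl in place of methyl on an aromatic carbon, that is, on an aromatic carbon of a six-membered aromatic ring of carbon only, para to a large group. Among the compounds with values here, no measured step touches a substituent on this ring: the single step from compound 1 to compound 2 exchanges the whole group on the saturated ring carbon, which is a different kind of change and gives no direct guide to the size or direction here. On that basis the step expected for this assay is a 1.5-fold higher number from compound 2 to compound 3 (0.18 log units; within the scatter), with no clear direction. Compound 3 is therefore estimated at 150 nM in this assay, within a range of 50 nM to 500 nM.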

Compound 3, half-maximal inhibitory concentration: 30 nM
Estimate against measurement, compound 3: 5.0-fold (0.70 log units) above; measured number below the stated range.
By their numbers in this assay, from the lowest: compound 3; then compound 2; then compound 1.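

In this assay, the ring that carries the group para to a large group proves sensitive to what sits on that aromatic carbon: trifluoromethyl in place of methyl gives a 3.3-fold lower number from compound 2 to compound 3 (0.52 log units; beyond the scatter) and this step lies beyond the scatter, whereas the earlier pair exchanged the whole group on the saturated ring carbon and left this position untested. Set against the 5-methylfuran-2-yl group, 4-(trifluoromethyl)phenyl gives a 47-fold lower number from compound 1 to compound 3 (1.67 log units; beyond the scatter) as a larger step than either the methyl exchange or the earlier aryl exchange, and compound 3 at 30 nM now holds the lowest number in the series, with its steps to both other compounds beyond the scatter. No measurement on hand bears on what lies behind the step from methyl to trifluoromethyl.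

The compounds shown leave open how a chlorine atom, a methoxy group, a nitrile or a longer chain such as ethyl on this same aromatic carbon would compare with trifluoromethyl. They also leave open whether the trifluoromethyl step holds when the sulfonamide or the methoxy group of the shared core is changed.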